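From 4-iodophenyl to 3-chlorophenyl on an amide-type nitrogen

The source may report more compounds than this note shows. Statements on the series, on what has been measured and on what is new or still open speak of the compounds shown alone.

Among the measured compounds shown here, in a physicochemical assay, with a stated time of 6 min (a higher number here means a weaker inhibitor, a lower number a stronger inhibitor), compound 1 (`O=C(Nc1ccc(I)cc1)Nc1nc(-c2cc3ccccc3o2)cs1`) reads 62000 nM and holds the lower of only two numbers so far. The other, compound 2 (`O=C(Nc1cccc([N+](=O)[O-])c1)Nc1nc(-c2cc3cc(Br)ccc3o2)cs1`), reads 159000 nM and so stands above compound 1 by more than the usual scatter. For the measured compounds named here, no two measured compounds differ in one place only, so no measured step shows what a single exchange does here.

Compound 3 (`O=C(Nc1cccc(Cl)c1)Nc1nc(-c2cc3ccccc3o2)cs1`) has not yet been measured. It keeps the core of compound 1 and carries 3-chlorophenyl in place of 4-iodophenyl on an amide-type nitrogen as its only difference. With nothing measured for this exchange, no direction can be argued from the data, and a change beyond the scatter in this assay is not expected. The expected step of a 1.3-fold higher number from compound 1 to compound 3 (0.11 log units; within the scatter) is accordingly small. For compound 3 the estimated value is 80000 nM with an expected range from 30000 nM to 200000 nM once it is measured.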

Compound 3, half-maximal inhibitory concentration: 14100 nM
Estimate against measurement, compound 3: 5.7-fold (0.75 log units) above; measured number outside the range, below it.
By their numbers in this assay, from the lowest: compound 3; then compound 1; then compound 2.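

In this assay, the exchange of 4-iodophenyl for 3-chlorophenyl on an amide-type nitrogen gives the first single-place step available, a 4.4-fold lower number from compound 1 to compound 3 (0.64 log units; beyond the scatter), showing that the number responds to what this position carries. The response appears even though the group that leaves and the group that enters have the same count of heavy atoms, one six-membered aromatic ring of carbon only, no hydrogen-bond donors or acceptors and no net charge; what differs between them is the halogen and the place it occupies on the ring. No measurement at hand accounts for this step, and the reason for it remains unexplained.

Since the halogen and its place on the ring change together in this one step, the compounds shown cannot say how much of the difference belongs to either. They also leave open how the number would respond at this position to a phenyl ring carrying an amine or a carboxylic acid in place of the halogen, or to a longer chain in place of the phenyl ring itself.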